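The source may hold more compounds than are shown below. What is called first, only, known or untested is meant among the compounds shown, and "the series" means these compounds.

Measured so far in an ADME assay for lipophilicity; on this read-out higher numbers stand for higher lipophilicity and lower numbers for lower lipophilicity

compound 1 `CCCOCc1cc(=O)c(O)co1` gives 0.3
compound 2 `Cc1cc(=O)c(O)c(C)o1` gives 0.44

Within the data shown here, these are the only two measured compounds, and in this assay compound 2 stands at 0.44 within the usual scatter of compound 1 at 0.3 so the two cannot be told apart on this read-out. They also differ in more than one place, so the pair offers no measured step to reason from.

Compound 3 `CCc1oc(C)cc(=O)c1O` has not yet been measured. It departs from compound 2 by a single change (methyl in place of hydrogen on a saturated chain carbon bound to an aromatic carbon): methyl in place of hydrogen on a saturated chain carbon bound to an aromatic carbon, which also reads as methyl to ethyl.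

Among the measured compounds shown here, with no measured step for this change, the expectation rests on the structural change alone. An upward step beyond the scatter is expected, estimated as a number 0.46 log units higher from compound 2 to compound 3 (beyond the scatter) in this assay starting from compound 2 at 0.44 for this one added carbon. In this assay the estimate for compound 3 is an expected 0.9 with a likely range from 0.6 to 1.25 still to be tested by measurement.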

Compound 3, distribution coefficient: 1.07
Compound 3: middle estimate off by 0.17 log units, on the low side; the measured number falls inside the stated range.
By their numbers in this assay, from the lowest: compounds 1 and 2 (each within the scatter of the next); then compound 3.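

In this assay, among these compounds, this is the first change in one place that can be read, since the two earlier compounds differ in more than one place: methyl in place of hydrogen on a saturated chain carbon bound to an aromatic carbon, which also reads as methyl to ethyl, gives a number 0.63 log units higher from compound 2 to compound 3 (beyond the scatter). The earlier compounds shown here could not be told apart on this read-out, whereas this position shows that a single added carbon can move the number beyond the scatter. Nothing at hand explains why the step has this size.

This single step cannot say whether a longer chain such as propyl on this same carbon would carry the rise further, or whether the same methyl to ethyl change would give a similar step on a compound with a different substituent pattern, such as compound 1. From the compounds shown here alone, what an amine or a carboxylic acid on this saturated chain carbon would do to the number in this assay also stays open.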